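This account rests on a few compounds, and the source may have more. Where it says the series, first, only, none or still open, it means among the compounds named here.

Compound 1 `CN1CCN(C(=O)/C=C/c2ccncc2-c2ccc3ccccc3c2)CC1`: 101%
Compound 2 `Cn1ncc2ccc(-c3cnccc3/C=C/C(=O)N3CCOCC3)cc21`: 89%

In an assay on a protein complex for inhibition of CDK8/Cyclin C (Homo sapiens), with a stated time of 1 h, tested at 10 uM (a lower number here means less inhibition, a higher number more inhibition at the concentration tested (going by the name of the read-out)), compound 1 gives 101%, the higher of the two numbers shown. Going by the values given here, compound 2 gives 89% in this assay, a number that lies below that of compound 1 by more than the usual scatter; no single structural step between compound 1 and compound 2 is recorded, so only the two values themselves can be set side by side. Compound 3 `O=C(/C=C/c1ccncc1-c1ccc2ccccc2c1)NC1CC1` has not yet been measured in this assay. Compound 3 differs from compound 1 in one place: cyclopropylamino in place of 4-methylpiperazin-1-yl on a carbonyl carbon. Everything else, the shared core with its double-bonded chain carbon and the carbonyl it carries, remains the same. Because compound 1 gives 101%, a high number in this assay, the step of a number 7 percentage points lower from compound 1 to compound 3 (within the scatter) is expected to be small, downward if anything, and most likely within the scatter. Compound 3 is therefore estimated at 94% in this assay, with a range from 78% to 104%.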

Compound 3, a percentage reported as inhibition, at one concentration (the size of the read-out at that concentration, not a potency): 102%
Compound 3: the middle estimate sits 8 percentage points below what was measured, within the range that was stated.
By their numbers in this assay, from the lowest: compound 2; then compounds 1 and 3 (each within the scatter of the next).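

Replacing 4-methylpiperazin-1-yl with cyclopropylamino on a carbonyl carbon gives, in this assay, a number 1 percentage points higher from compound 1 to compound 3 (within the scatter), so the two compounds cannot be told apart in this read-out. Going by these compounds alone, this is the first one-place comparison, and it shows that this position accepts a large change in the group attached: 7 heavy atoms give way to 4, a six-membered ring with 2 hetero atoms gives way to a three-membered ring of carbon only, and a hydrogen-bond donor enters, all with the number staying within the scatter. The read-out is taken at one concentration and is not a potency, so any difference between compound 1 and compound 3 at lower concentrations stays out of sight. Nothing shown explains why the two groups read alike. The compounds shown leave open whether the carbonyl carbon would keep such a number with a hydroxyl group, as in a carboxylic acid, or with a longer chain such as n-butylamino. They also leave open whether the amide hydrogen matters, which N-methylcyclopropylamino at the same place would address.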